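Vinyl for Methoxycarbonyl: Cytotoxicity Expected Unchanged

The compounds below may be only part of what the source reports. "The series", "measured", "known", "first", "only" and "open" are said of these compounds alone.

In an ADME assay on PC-3 cells (Homo sapiens) for cytotoxicity, read by WST assay, tested at 100 uM (a lower number here means less inhibition, a higher number more inhibition at the concentration tested (going by the name of the read-out)), compound 2 `COC(=O)c1cccc(C(=O)N2CCCC(C(=O)Nc3ccc(Cl)cc3)C2)c1` gives 0%. This places it level with compound 1 `CSc1cccc(NC(=O)C2CCCN(C(=O)c3cc(C(F)(F)F)cc(C(F)(F)F)c3)C2)c1`, which gives 0%, and with compound 3 `O=C(Nc1cccc(S(=O)(=O)N2CCCC2)c1)C1CCCN(C(=O)c2cc(C(F)(F)F)cc(C(F)(F)F)c2)C1`, which gives 0%. Within the data shown here, the one measured step, no change at the digits printed from compound 1 to compound 3 (within the scatter), shows that replacing one group on an aromatic ring with a quite different one left the read-out where it was. Compound 4 `C=Cc1cccc(C(=O)N2CCCC(C(=O)Nc3ccc(Cl)cc3)C2)c1` differs from compound 2 by vinyl in place of methoxycarbonyl on an aromatic carbon. Among the measured compounds shown here, no measured step concerns this particular change, so the only guide is that all three measured compounds, carrying different aromatic substituents, sit at the same level. The expectation is therefore no step beyond the scatter, no change at the digits printed from compound 2 to compound 4 (within the scatter). Compound 4 is estimated at 0%, within -8% to 12%.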

Compound 4, a percentage reported as inhibition, at one concentration (the size of the read-out at that concentration, not a potency): 0%
Beside the measured number, compound 4's estimate shows no gap at the digits printed, and the stated range covers the measured number.
By their numbers in this assay, from the lowest: compounds 1, 2, 3 and 4 (each within the scatter of the next).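

In this assay, among these compounds, there is no change at the digits printed from compound 2 to compound 4 (within the scatter), the only measured change at this place on the aromatic ring. Methoxycarbonyl, with its two hydrogen-bond acceptors, gives way to the smaller vinyl, which has none, and the read-out stays at the same level. Nothing measured here accounts for this level. On these data alone, whether an amine or a carboxylic acid at this place would shift the read-out remains open. So does whether a longer chain here would leave it level.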